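Fluoro to Chloro on the Distal Phenyl Ring

The source may report more compounds than this note shows. Statements on the series, on what has been measured and on what is new or still open speak of the compounds shown alone.

Measured compounds in a functional assay on SMMC-7721 cells (Homo sapiens) for antiproliferative activity, read by MTT assay, with a stated time of 72 h; a lower number here means a stronger inhibitor, a higher number a weaker inhibitor:
compound 1 `Cc1nn(C)c(Oc2ccc(F)cc2)c1/C=N\OCc1c(Cl)c(-c2ccc(F)cc2)nn1C`, 6640 nM
compound 2 `Cc1ccc(Oc2c(/C=N\OCc3c(Cl)c(-c4ccc(F)cc4)nn3C)c(C)nn2C)cc1`, 5230 nM
compound 3 `Cc1nn(C)c(Oc2ccc(OC(F)(F)F)cc2)c1/C=N\OCc1c(Cl)c(-c2ccc(F)cc2)nn1C`, 5210 nM

Compound 1 gives the highest of the three numbers, though neither of its companions stands apart from it: the step of a 1.3-fold lower number from compound 1 to compound 2 (0.10 log units; within the scatter) and the step of a 1.3-fold lower number from compound 1 to compound 3 (0.11 log units; within the scatter) both stay within the scatter, as does the step of a 1.0-fold lower number from compound 2 to compound 3 (0.00 log units; within the scatter). All three measured differences sit on the phenyl ring joined through oxygen to the shared core.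

Compound 4 `Cc1nn(C)c(Oc2ccc(F)cc2)c1/C=N\OCc1c(Cl)c(-c2ccc(Cl)cc2)nn1C` differs from compound 1 by chloro in place of fluoro on an aromatic carbon, on an aromatic carbon of a six-membered aromatic ring of carbon only, para to a large group; read one bond further out, 4-fluorophenyl becomes 4-chlorophenyl. For the measured compounds named here, this ring is not the one varied in compounds 2 and 3, so no measured step bears directly on it. What the data do show is that single substituent swaps on an outer phenyl ring left this assay essentially unchanged. Compound 4 is therefore expected to show the step of a 1.1-fold lower number from compound 1 to compound 4 (0.04 log units; within the scatter), no clear shift beyond the scatter. The expected value for compound 4 is 6000 nM, within the range 2800 nM to 13000 nM.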

Compound 4, half-maximal inhibitory concentration: 3230 nM
For compound 4 the middle estimate is 1.9-fold (0.27 log units) above the measured one; the measured number falls inside the stated range.
By their numbers in this assay, from the lowest: compounds 4, 3, 2 and 1 (each within the scatter of the next, the first and the last beyond it).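

In this assay the change from 4-fluorophenyl to 4-chlorophenyl gives a 2.1-fold lower number from compound 1 to compound 4 (0.31 log units; beyond the scatter) and is the only step shown that passes beyond the scatter, if only modestly. For the compounds shown here, the swaps on the phenyl ring joined through oxygen stayed within the scatter, with a 1.3-fold lower number from compound 1 to compound 2 (0.10 log units; within the scatter) and a 1.3-fold lower number from compound 1 to compound 3 (0.11 log units; within the scatter) as their sizes, so the distal phenyl ring, untested by the earlier compounds, responds measurably to the exchange of one halogen for another. Nothing shown accounts for this shift.

Going by these compounds, whether bromo, an amine or a carboxylic acid at this same place would carry the trend further, or reverse it, remains open. Also open, on these data alone, is whether chloro in place of fluoro on the phenyl ring joined through oxygen would give a similar step.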